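Aryl carbonyl swap on compound 3

The compounds below may be only part of what the source reports. "The series", "measured", "known", "first", "only" and "open" are said of these compounds alone.

In an ADME assay on HEK293 cells (Homo sapiens) for cytotoxicity, read by MTT assay, with a stated time of 72 h (a lower number here means a stronger inhibitor, a higher number a weaker inhibitor), the values so far are
- compound 1 `O=C(CN1CCN(C(=O)c2ccc(Br)cc2)CC1)N1CCN(CCCc2c[nH]c3ccccc23)CC1` gives 71900 nM
- compound 2 `O=C(CN1CCN(C(=O)c2ccc(Br)cc2)CC1)N1CCN(CCCc2c[nH]c3ccc(F)cc23)CC1` gives 60500 nM
- compound 3 `COc1ccc2[nH]cc(CCCN3CCN(C(=O)CN4CCN(C(=O)c5ccc(Br)cc5)CC4)CC3)c2c1` gives 80500 nM

The gaps of a 1.1-fold higher number from compound 1 to compound 3 (0.05 log units; within the scatter) and a 1.3-fold higher number from compound 2 to compound 3 (0.12 log units; within the scatter) leave compound 3 unseparated from the other two. Among the compounds with values here, compound 4 `COc1ccc2[nH]cc(CCCN3CCN(C(=O)CN4CCN(C(=O)c5cccc(F)c5)CC4)CC3)c2c1` differs from compound 3 by 3-fluorophenyl in place of 4-bromophenyl on a carbonyl carbon and has no measurement yet. Those two steps and a 1.2-fold lower number from compound 1 to compound 2 (0.07 log units; within the scatter) are swaps on an aromatic carbon of the shared core. None changes the group on the carbonyl carbon, so they bear on this change only indirectly. No step beyond the scatter is expected in this assay in either direction. The expected step is a 1.1-fold lower number from compound 3 to compound 4 (0.03 log units; within the scatter) with no direction favoured. Compound 4 is estimated at 75000 nM within an expected range of 40000 nM to 130000 nM on this read-out.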

Compound 4, half-maximal inhibitory concentration: > 200000 nM
Compound 4 ended at the assay's limit (the forecaster's own chance of this, stated with the estimate: 15%); at least 2.6-fold (0.42 log units) between middle value and limit.
By their numbers in this assay, from the lowest: compounds 2, 1 and 3 (each within the scatter of the next). At a limit, above all of these: compound 4.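

In this assay, replacing the group on the carbonyl carbon gives an at least 2.4-fold higher number from compound 3 to compound 4 (0.39 log units; beyond the scatter) and is the only step shown that lies beyond the scatter. The swaps on an aromatic carbon of the shared core among compound 1, compound 2 and compound 3 all stayed within it, so this position is the one that moves the read-out. The value of compound 4 is a limit, not a number: the limit of > 200000 nM in this assay, at which 1 of the 4 values shown sits.

The change from 4-bromophenyl to 3-fluorophenyl alters the halogen and its place together, and the compounds shown do not separate the two. Also open, from the compounds shown here alone, is how 3-bromophenyl, 4-fluorophenyl or an aminophenyl group on this carbonyl carbon would read.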